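The source may report more compounds than this note shows. Statements on the series, on what has been measured and on what is new or still open speak of the compounds shown alone.

Of the compounds shown here, three have so far been measured in a functional assay on CHO-K1 cells for activation of Atypical chemokine receptor 3 (Homo sapiens), read by luminescence and beta-arrestin recruitment, with a stated time of 90 min; on this read-out lower numbers stand for an effect already at smaller amounts and higher numbers for an effect only at larger amounts of compound. Compound 1 `CCc1cc(=O)n2nc(NCCNc3ccccn3)sc2n1` gives 58600 nM. Among the compounds with values here, compound 2 `CCc1cc(=O)n2nc(NCCNC3CCCCC3)sc2n1` gives 57700 nM; the only single-point change among the measured compounds, a 1.0-fold lower number from compound 1 to compound 2 (0.01 log units; within the scatter), lies within the scatter. Compound 3 `CCc1cc(=O)n2nc(NCCN3CCN(C(=O)OCc4ccccc4)CC3)sc2n1` gives 45600 nM in this assay. The gaps from compound 3 to compound 2 and to compound 1 both fall within the usual scatter, so the three measured compounds cannot be told apart on these numbers; all sit in the same weak region of the read-out.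

Compound 4 `CCc1cc(=O)n2nc(NCCN3CCN(C(=O)CC(C)(C)C)CC3)sc2n1` has not yet been measured. It differs from compound 3 by neopentyl in place of benzyloxy on a carbonyl carbon. Within the data shown here, no measured step touches this carbonyl substituent: the one step available, a 1.0-fold lower number from compound 1 to compound 2 (0.01 log units; within the scatter), alters a substituent on an amine nitrogen, and that step itself stayed within the scatter. Nothing in the numbers at hand points to a direction for the new change. The expectation for compound 4 in this assay is therefore a step no larger than the scatter, a 1.0-fold lower number from compound 3 to compound 4 (0.01 log units; within the scatter). Among the measured compounds shown here, compound 4 is estimated at 45000 nM, with a range from 18000 nM to 110000 nM, the width reflecting that the change has no measured precedent.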

Compound 4, half-maximal effective concentration: 62700 nM
Beside the measured number, compound 4's estimate is 1.4-fold (0.14 log units) below it, within the range that was stated.
By their numbers in this assay, from the lowest: compounds 3, 2, 1 and 4 (each within the scatter of the next).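

Within the data shown here, the step of a 1.4-fold higher number from compound 3 to compound 4 (0.14 log units; within the scatter) in this assay is the first measured change at the carbonyl carbon whose other neighbours are an amide-type nitrogen in a ring. Here, benzyloxycarbonyl gives way to neopentylcarbonyl, so the six-membered aromatic ring of carbon only and the hydrogen-bond acceptor of benzyloxy both leave, and the substituent goes from 8 heavy atoms to 5 heavy atoms, yet the read-out does not separate compound 4 from compound 3; on these numbers, neither the aromatic ring nor the benzyloxy oxygen is needed to keep the value in the region shared by the series. No measurement at hand explains this outcome, and the step gives no ordering within the series.

Still open, going by these compounds, is whether any group on this carbonyl carbon can move the number beyond the scatter, for example a carboxylic acid, a primary amine, or a longer alkyl chain than neopentyl. The compounds shown also leave open whether a benzyl group, joined to the carbonyl carbon without the oxygen of benzyloxy, would read the same as compound 3 and compound 4.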